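Replacing neopentyloxy with 3-methoxypropyl in a urea series

A few compounds are considered here, and "the series" means these few. Any claim that something is new, unique, unknown or untested is made for them only; others in the source may bear on it.

Measured compounds:
Compound 1, `CC(C)(C)CCc1cc(C(F)(F)F)ccc1CNC(=O)Nc1cccc2[nH]ncc12`: 4.3 nM
Compound 2, `CC(C)(C)COc1nc(C(F)(F)F)ccc1CNC(=O)Nc1cccc2[nH]ncc12`: 6 nM

Of the compounds shown here, two that share a urea core have been tested in a functional assay for antagonist activity at transient receptor potential cation channel subfamily V member 1 (Homo sapiens); on this read-out higher numbers stand for weaker inhibition and lower numbers for stronger inhibition. Compound 1 gives 4.3 nM, and compound 2 gives 6 nM. The gap between them is within the usual scatter of such measurements, so compound 2 stands alongside compound 1 and neither can be ranked above the other on these numbers.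

Compound 3, `COCCCc1nc(C(F)(F)F)ccc1CNC(=O)Nc1cccc2[nH]ncc12`, has not yet been measured. It differs from compound 2 in one place: 3-methoxypropyl in place of neopentyloxy on an aromatic carbon. Going by the values given here, the group that leaves and the group that enters are of similar size, each without a ring and each with one hydrogen-bond acceptor, but no measured pair shows what this exchange does on this read-out.

Given the absence of a measured step of this kind, compound 3 is expected to give 20 nM, with a range from 6 nM to 70 nM. This estimate means a step of a 3.3-fold higher number from compound 2 to compound 3 (0.52 log units; beyond the scatter), expected to go modestly toward weaker inhibition, slightly beyond the scatter.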

Compound 3, half-maximal inhibitory concentration: 12 nM
Compound 3: middle estimate off by 1.7-fold (0.22 log units), on the high side, within the range that was stated.
By their numbers in this assay, from the lowest: compounds 1, 2 and 3 (each within the scatter of the next, the first and the last beyond it).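

In this assay, the exchange of neopentyloxy for 3-methoxypropyl on an aromatic carbon next to the ring nitrogen comes out as a 2.0-fold higher number from compound 2 to compound 3 (0.30 log units; within the scatter) and so leaves the two compounds indistinguishable on this read-out. This single pair shows that the position can carry either of these two chains, one joined to the aromatic carbon through oxygen and the other through carbon, with no change that can be read beyond the usual scatter. Nothing available explains this outcome or shows what either group does at this position.

As far as these compounds go, what happens at this aromatic carbon with a different kind of group, such as a primary amine, a carboxylic acid or a longer ether chain, remains open. From the compounds shown here alone, it is also open whether 3-methoxypropyl in place of neopentyloxy would give a similar step on a different core, since this exchange is seen only once, between compounds that share the same core and differ only in this one place.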